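Swapping a sulfonyl for a carbonyl in a cytotoxicity series

A few compounds are considered here, and "the series" means these few. Any claim that something is new, unique, unknown or untested is made for them only; others in the source may bear on it.

Of the compounds shown here, three sharing one core have been tested in an ADME assay on MT4 cells (Homo sapiens) for cytotoxicity, read by MTT assay, with a stated time of 5 days; on this read-out lower numbers stand for higher toxicity in this test and higher numbers for lower toxicity in this test. Compound 1 `Cc1cc(C#N)cc(C)c1Oc1nc(NC2CCC(NC(=O)c3ccccc3)CC2)nc2ccsc12` gives 3930 nM, compound 2 `Cc1cc(C#N)cc(C)c1Oc1nc(NC2CCC(NS(=O)(=O)c3ccc(C#N)cc3)CC2)nc2ccsc12` gives 9290 nM, and compound 3 `Cc1cc(C#N)cc(C)c1Oc1nc(NC2CCC(NC(=O)c3ccc(C#N)cc3)CC2)nc2ccsc12` gives 2620 nM. Compound 2 thus has the highest number of the three, meaning the least toxicity in this assay: the nearest neighbour is a 2.4-fold higher number from compound 1 to compound 2 (0.37 log units; beyond the scatter), and the furthest is a 3.5-fold lower number from compound 2 to compound 3 (0.55 log units; beyond the scatter).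

Compound 4 `Cc1cc(C#N)cc(C)c1Oc1nc(NC2CCC(NC(=O)c3cccc(C(F)(F)F)c3)CC2)nc2ccsc12` has not yet been measured. It differs from compound 2 in one place: (3-(trifluoromethyl)phenyl)carbonyl in place of (4-cyanophenyl)sulfonyl on an amine nitrogen. For the measured compounds named here, two measured steps bear on this change. Exchanging the sulfonyl for a carbonyl while keeping the same cyanophenyl ring gave a 3.5-fold lower number from compound 2 to compound 3 (0.55 log units; beyond the scatter), a step beyond the scatter towards more toxicity. Altering the substituent on the benzoyl ring, cyano in place of hydrogen, gave a 1.5-fold lower number from compound 1 to compound 3 (0.18 log units; within the scatter), which lies within the scatter. Going by the values given here, no measured compound carries a trifluoromethyl group, so the contribution of that group is unknown. The change to compound 4 is therefore expected to behave mainly like the earlier sulfonyl-to-carbonyl exchange, giving an estimated 3.1-fold lower number from compound 2 to compound 4 (0.49 log units; beyond the scatter). For compound 4 the value in this assay is estimated at 3000 nM, with a range from 1000 nM to 9000 nM.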

Compound 4, half-maximal cytotoxic concentration: 3240 nM
Compound 4: the middle estimate sits 1.1-fold (0.03 log units) below what was measured; the range from low to high includes it.
By their numbers in this assay, from the lowest: compounds 3, 4 and 1 (each within the scatter of the next); then compound 2.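

In this assay, a second carbonyl compound now shows the sulfonyl-to-carbonyl exchange going the same way with a different ring attached, with a 2.9-fold lower number from compound 2 to compound 4 (0.46 log units; beyond the scatter), so the move towards more toxicity seen with compound 3 does not depend on keeping the 4-cyanophenyl ring. Among the carbonyl compounds, the ring itself makes no readable difference: 3-(trifluoromethyl)phenyl in place of 4-cyanophenyl gives a 1.2-fold higher number from compound 3 to compound 4 (0.09 log units; within the scatter), and trifluoromethyl in place of hydrogen gives a 1.2-fold lower number from compound 1 to compound 4 (0.08 log units; within the scatter). At this amine nitrogen, the gap in these four compounds therefore follows the linking group, with compound 2 apart from compound 1, compound 3 and compound 4, which stay within the scatter of one another.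

Nothing measured here explains why the sulfonyl compound stands apart. With only one sulfonyl compound shown, it remains open whether the gap would hold for a sulfonyl carrying the 3-(trifluoromethyl)phenyl ring, and whether a benzoyl ring bearing an amine or a carboxylic acid, or a longer alkyl chain in place of the ring, would stay in the same range.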